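Working notes: sulfur side chain, compound 2 to compound 3

This account rests on a few compounds, and the source may have more. Where it says the series, first, only, none or still open, it means among the compounds named here.

Measured in a functional assay on PC-3 cells (Homo sapiens) for inhibition, read by MTT assay, with a stated time of 48 h; a higher number here means a weaker inhibitor, a lower number a stronger inhibitor:
Compound 1 `COc1cc(-c2nnc(SC)n2-c2ccc(N(C)C)cc2)cc(OC)c1OC` gives > 60000 nM (a limit)
Compound 2 `COc1cc(-c2nnc(SCc3ccc(C)cc3)n2-c2ccc(N(C)C)cc2)cc(OC)c1OC` gives 37300 nM (a number)

For the measured compounds named here, compound 2 is the only compound with a number so far in this assay and its value stands alone. The next structure, compound 3 `COc1cc(-c2nnc(SCC(=O)c3ccccc3)n2-c2ccc(N(C)C)cc2)cc(OC)c1OC`, differs from it as follows: benzoyl in place of 4-methylphenyl on a saturated chain carbon bound to a sulfur and so carries benzoyl in place of 4-methylphenyl on a saturated chain carbon bound to a sulfur. Going by the values given here, the one measured step at that place, an at least 1.6-fold lower number from compound 1 to compound 2 (0.20 log units; that floor lies within the scatter), lies within the scatter. Its starting point is a limit of > 60000 nM in this assay, at which 1 of the 2 values shown sits, and not a number. No step beyond the scatter is therefore expected in this assay and no direction can be favoured. The estimated step is a 1.1-fold lower number from compound 2 to compound 3 (0.05 log units; within the scatter) on this reading. Compound 3 is estimated at 33000 nM with 13000 nM to 60000 nM as the expected range.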

Compound 3, half-maximal inhibitory concentration: 38600 nM
For compound 3 the middle estimate is 1.2-fold (0.07 log units) below the measured one, within the range that was stated.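

In this assay, benzoyl in place of 4-methylphenyl on a saturated chain carbon bound to a sulfur gives a 1.0-fold higher number from compound 2 to compound 3 (0.01 log units; within the scatter), so two different side chains at this place now carry numbers that cannot be told apart. The entering benzoyl brings a carbonyl and one hydrogen-bond acceptor that 4-methylphenyl lacks, and no step beyond the scatter comes with them. Against hydrogen at this place only a floor can be read, an at least 1.5-fold lower number from compound 1 to compound 3 (0.19 log units; that floor lies within the scatter), and compound 1 stands at a limit and not a number: the limit of > 60000 nM in this assay, at which 1 of the 3 values shown sits.

Still open, on these data alone, is whether an amine, a carboxylic acid or a longer chain at this place would give a step beyond the scatter. Also open, as far as these compounds go, is how far the real steps from compound 1 reach, as only their floors can be read.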